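Chlorophenyl variation in a trimethoxyphenyl antiproliferative series

A few compounds are considered here, and "the series" means these few. Any claim that something is new, unique, unknown or untested is made for them only; others in the source may bear on it.

The three measured compounds share a core bearing a trimethoxyphenyl group and a variable aryl group. Compound 1 is `COc1cc(-n2cnc3ccc(-c4ccccc4Cl)cc32)cc(OC)c1OC`; in a functional assay on A549 cells (Homo sapiens) for antiproliferative activity, read by MTT assay, with a stated time of 72 h (a higher number here means a weaker inhibitor, a lower number a stronger inhibitor), compound 1 gives > 10000 nM, a limit of the assay rather than a number. Compound 2 is `COc1cc(-n2cnc3ccc(-c4cccc(Cl)c4)cc32)cc(OC)c1OC`; in this assay compound 2 gives 7050 nM. Compound 3 is `COc1cc(-c2ccc3ncn(-c4cc(OC)c(OC)c(OC)c4)c3c2)cc(OC)c1OC`; in this assay compound 3 gives > 10000 nM, again a limit. Going by the values given here, compound 2 thus holds the only numerical value in the set, the other two sitting at the limit of > 10000 nM in this assay, at which 2 of the 3 values shown sit. Among the compounds with values here, the single measured step with one change, an at least 1.4-fold lower number from compound 1 to compound 2 (0.15 log units; that floor lies within the scatter), stays within the scatter.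

Compound 4 is `COc1cc(-n2cnc3ccc(-c4ccc(Cl)cc4Cl)cc32)cc(OC)c1OC`. It differs from compound 2 in one place: 2,4-dichlorophenyl in place of 3-chlorophenyl on an aromatic carbon. Within the data shown here, only the step from compound 1 to compound 2 bears on this change, and it was small; the 2,4-dichlorophenyl of compound 4 includes the chlorine of the 2-chlorophenyl of compound 1, whose value was a limit. No step beyond the scatter is expected, and a limit is a real possibility. Compound 4 is expected to give 9000 nM in this assay, within 3500 nM to 25000 nM. The step from compound 2 to compound 4 is therefore estimated as a 1.3-fold higher number from compound 2 to compound 4 (0.11 log units; within the scatter).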

Compound 4, half-maximal inhibitory concentration: > 10000 nM
Compound 4 ended at the assay's limit (the forecaster's own chance of this, stated with the estimate: 50%); middle value at least 1.1-fold (0.04 log units) from the limit.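

In this assay compound 4 gives > 10000 nM, which is a limit of the assay and not a number. Placing 2,4-dichlorophenyl where compound 2 carries 3-chlorophenyl gives an at least 1.4-fold higher number from compound 2 to compound 4 (0.15 log units; that floor lies within the scatter), so the data fix only a floor that lies within the scatter and do not establish a real loss of activity, while the step from compound 1 to compound 4, which adds a chloro on an aromatic carbon, cannot be read, as both values are limits. The new result therefore adds a second chlorophenyl compound at the limit and leaves compound 2 as the only compound in the series with a measured number: the limit of > 10000 nM in this assay, at which 3 of the 4 values shown sit.

On these data alone, how far compound 1, compound 3 and compound 4 actually lie from compound 2 remains open, and a single numerical value gives no basis for ranking substitution on this phenyl ring. As far as these compounds go, it is also open whether an amine or a carboxylic acid in place of the chloro of compound 2 would give a value clearly separated from the scatter in this assay.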